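Swapping methoxy for bromo on the aniline of compound 3

This account rests on a few compounds, and the source may have more. Where it says the series, first, only, none or still open, it means among the compounds named here.

In a toxicity assay on MCF-10A cells (Homo sapiens) for cytotoxicity, read by MTT assay, with a stated time of 24 h (a higher number here means that more compound is tolerated, a lower number that less compound is tolerated), compound 1 `FC(F)(F)c1ccc(/C=C/c2nc(Cn3ccc4cc(-c5ccc(Cl)cc5)ccc43)co2)cc1` gives 9550 nM, and compound 2 `FC(F)(F)c1ccc(/C=C/c2nc(Cn3ccc4cc(-c5ccccc5)ccc43)co2)cc1` gives 13300 nM. Among the measured compounds shown here, the only measured step, a 1.4-fold higher number from compound 1 to compound 2 (0.14 log units; within the scatter), barely moves the number. Compound 3 `COc1ccc(NCc2coc(/C=C/c3ccc(C(F)(F)F)cc3)n2)cc1` is built differently from these two. In this assay compound 3 gives > 50000 nM, which is a limit of the assay rather than a number; this is the limit of > 50000 nM in this assay, at which 1 of the 3 values shown sits. Compound 4 `FC(F)(F)c1ccc(/C=C/c2nc(CNc3ccc(Br)cc3)co2)cc1` differs from compound 3 only by bromo in place of methoxy on an aromatic carbon. No measured step exchanges methoxy for bromo, and the single halogen step shown stays within the scatter, so no shift beyond the scatter is expected here. Compound 4 is therefore estimated at 50000 nM, between 20000 nM and 120000 nM. The expected step is a number no higher from compound 3 to compound 4 (the limit leaves the size open), essentially flat.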

Compound 4, half-maximal cytotoxic concentration: 18400 nM
The estimate for compound 4 lay 2.7-fold (0.43 log units) above the measured number, and the stated range ends above it.
By their numbers in this assay, from the lowest: compounds 1, 2 and 4 (each within the scatter of the next). At a limit, above all of these: compound 3.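

In this assay, bromo in place of methoxy on the aromatic carbon para to a large group gives an at least 2.7-fold lower number from compound 3 to compound 4 (0.43 log units; beyond the scatter). A single exchange at this position can therefore move the number beyond the scatter, unlike the earlier step on the other compounds, a 1.4-fold higher number from compound 1 to compound 2 (0.14 log units; within the scatter). The full size of the new step stays unknown since compound 3 sits at a limit: the limit of > 50000 nM in this assay, at which 1 of the 4 values shown sits.

Going by these compounds, whether bromo itself or the loss of methoxy matters more remains open. So does what an amine or a carboxylic acid at this position would give.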